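Methoxy for Fluoro on Two Related Cores

A few compounds are considered here, and "the series" means these few. Any claim that something is new, unique, unknown or untested is made for them only; others in the source may bear on it.

Of the compounds shown here, three have so far been measured in a functional assay on A549 cells (Homo sapiens) for inhibition, read by MTT assay, with a stated time of 72 h; on this read-out lower numbers stand for stronger inhibition and higher numbers for weaker inhibition. Compound 1 `C=C(c1ccc(OC)c(F)c1)C1COC2(CCCC2)OO1` gives 9700 nM, compound 2 `C=C(c1ccc(F)c(F)c1)C1COC2(CCCC2)OO1` gives 11700 nM, and compound 3 `C=C(c1ccc(F)c(F)c1)C1COC2(CCCCC2)OO1` gives 7880 nM. Compound 1 and compound 2 share one core and differ in a single place: methoxy in place of fluoro on an aromatic carbon. That change made a step of a 1.2-fold lower number from compound 2 to compound 1 (0.08 log units; within the scatter). Compound 3 carries a second core; how the core of compound 3 differs from the core of compound 2 is not broken down here. All three values lie within the usual scatter of one another, so no order among them can be read from these numbers.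

Compound 4 `C=C(c1ccc(OC)c(F)c1)C1COC2(CCCCC2)OO1` has not yet been measured. It is related to compound 3 by methoxy in place of fluoro on an aromatic carbon. The surroundings of the changed position read the same as in the pair of compound 2 and compound 1, so this is the same change, now carried out on the second core. Among the compounds with values here, only one earlier instance of it exists, and that instance stayed within the scatter. Within the data shown here, the expected step from compound 3 to compound 4 is accordingly a 1.2-fold lower number from compound 3 to compound 4 (0.06 log units; within the scatter), because the single earlier instance gave a 1.2-fold lower number from compound 2 to compound 1 (0.08 log units; within the scatter). Compound 4 is therefore estimated at 6800 nM in this assay, with a likely range from 3400 nM to 13600 nM.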

Compound 4, half-maximal inhibitory concentration: 6530 nM
Estimate against measurement, compound 4: 1.0-fold (0.02 log units) above; measured number inside the range.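

In this assay, methoxy in place of fluoro on the second core gave a 1.2-fold lower number from compound 3 to compound 4 (0.08 log units; within the scatter), and set beside the earlier instance on the first core, the two steps agree: the same change on two cores in this assay, a 1.2-fold lower number (0.08 log units; within the scatter) from compound 2 to compound 1 and a 1.2-fold lower number (0.08 log units; within the scatter) from compound 3 to compound 4, 1.0-fold (0.00 log units) apart, within the scatter of two such steps

On these two cores, then, the change behaved alike, and nothing in the numbers marks one core as responding differently from the other. This agreement is weak evidence of transfer, however, since both steps lie within the scatter, so neither shows that the change moves the number at all, and two small steps would match whether or not the core has any influence on the change.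

The compounds shown leave open whether any group at this position, on the aromatic carbon para to a large group, can shift the number beyond the scatter, for instance an amine, a carboxylic acid or a longer chain such as ethoxy in place of methoxy. They also leave open whether a step of clear size would carry from one core to the other, and whether the same change would read alike on any further core.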